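Shrinking the Macrocyclic Amine Ring of Compound 3

This account rests on a few compounds, and the source may have more. Where it says the series, first, only, none or still open, it means among the compounds named here.

Measured compounds in a functional assay on A-431 cells (Homo sapiens) for antiproliferative activity, read by MTT assay, with a stated time of 72 h; on this read-out higher numbers stand for weaker inhibition and lower numbers for stronger inhibition:
- compound 1 `COc1cc2ncnc(Nc3cccc(C(F)(F)F)c3)c2cc1OCCCN1CCNCCNCCNCC1` gives 1950 nM
- compound 2 `COc1cc2ncnc(Nc3cccc(F)c3)c2cc1OCCCN1CCNCCNCCNCC1` gives 1860 nM
- compound 3 `COc1cc2ncnc(Nc3ccc(C#N)cc3F)c2cc1OCCCN1CCNCCNCCNCC1` gives 6370 nM

All three share one core and differ only in the aromatic amine at its tip. Compound 3 carries the 4-cyano-2-fluorophenyl group and has the highest number of the three, which in this assay means the weakest inhibition: the step of a 3.3-fold higher number from compound 1 to compound 3 (0.51 log units; beyond the scatter) and the step of a 3.4-fold higher number from compound 2 to compound 3 (0.53 log units; beyond the scatter) both go beyond the scatter, whereas the step of a 1.0-fold lower number from compound 1 to compound 2 (0.02 log units; within the scatter) does not.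

Compound 4 `COc1cc2ncnc(Nc3ccc(C#N)cc3F)c2cc1OCCCN1CCNCCNCC1` keeps that same aromatic amine and changes the other end of the molecule instead: a group of 9 heavy atoms (6 carbon, 3 nitrogen; one nine-membered non-aromatic ring with 3 hetero atoms) in place of a group of 12 heavy atoms (8 carbon, 4 nitrogen; one twelve-membered non-aromatic ring with 4 hetero atoms), on a saturated chain carbon, three bonds along the chain from an oxygen on an aromatic ring. For the measured compounds named here, none of the measured steps touches this part of the molecule; all of them alter the aromatic amine, so there is no measured step that bears directly on this change. The expectation for compound 4 can therefore only start from compound 3 and allow for a broad range. Compound 4 is estimated at 6000 nM, with a range from 2500 nM to 15000 nM, which means an expected step of a 1.1-fold lower number from compound 3 to compound 4 (0.03 log units; within the scatter) from compound 3, in other words no step beyond the scatter is expected in either direction.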

Compound 4, half-maximal inhibitory concentration: 12700 nM
Compound 4: middle estimate off by 2.1-fold (0.33 log units), on the low side; measured number inside the range.
By their numbers in this assay, from the lowest: compounds 2 and 1 (each within the scatter of the next); then compounds 3 and 4 (each within the scatter of the next).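

In this assay, for the compounds shown here, the first measured change at this end of the molecule, a nine-membered ring in place of a larger ring on the chain, gives a 2.0-fold higher number from compound 3 to compound 4 (0.30 log units; within the scatter). Going by these compounds alone, for the 4-cyano-2-fluorophenyl amine, then, this smaller ring gives a number that stays within the usual scatter of the larger ring's, something the earlier compounds could not show, since all of them carry the larger ring and differ only in the aromatic amine. No measurement given here offers an explanation for this step.

Going by these compounds, it remains open whether the nine-membered ring would give a similar result alongside the 3-fluorophenyl amine of compound 2. On these data alone, it is also open how an open-chain group such as dimethylamino would compare at the end of this chain.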